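The source may hold more compounds than are shown below. What is called first, only, known or untested is meant among the compounds shown, and "the series" means these compounds.

Of the compounds shown here, two have been measured so far, and a third waits its turn. Compound 1 `ClCc1cccc(Cn2cnc3c(Cl)nc(Cl)nc32)c1` carries two chloro groups on its bicyclic core and a benzyl chain bearing a chloromethyl group. Compound 2 `ClCc1cccc(Cn2cnc3nc(Cl)nc(Cl)c32)c1` has the same pieces, joined to the core through the other ring nitrogen. In a functional assay on NCI-H226 cells (Homo sapiens) for cytotoxicity, read by sulforhodamine B assay, with a stated time of 48 h (a lower number here means a stronger inhibitor of growth, a higher number a weaker inhibitor of growth), compound 1 gives 3230 nM, the higher of the two numbers, so it is the weaker of the pair at slowing the growth of these cells. In this assay compound 2 gives 1280 nM, a lower number that lies beyond the scatter, so compound 2 is the stronger inhibitor of the two.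

Compound 3 `Nc1nc(Cl)c2ncn(Cc3cccc(CCl)c3)c2n1` is built from compound 1 by one replacement: amino in place of chloro on an aromatic carbon. For the measured compounds named here, no measured pair in this small set shows what such a swap does, so the direction of the step can only be guessed. A small weakening seems most likely, with a wide margin: the step from compound 1 to compound 3 is expected to be a 1.9-fold higher number from compound 1 to compound 3 (0.27 log units; within the scatter). Compound 3 is therefore estimated to give 6000 nM in this assay, most plausibly between 1500 nM and 25000 nM.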

Compound 3, concentration for 50% growth inhibition: 10700 nM
Estimate against measurement, compound 3: 1.8-fold (0.25 log units) below, and the stated range covers the measured number.
By their numbers in this assay, from the lowest: compound 2; then compound 1; then compound 3.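

For the compounds shown here, this is the first measured swap at this place, the aromatic carbon between two ring nitrogen atoms, and in this assay replacing chloro with amino gives a 3.3-fold higher number from compound 1 to compound 3 (0.52 log units; beyond the scatter). The step is beyond the usual scatter, so at this position on the core of compound 1, amino gives a weaker inhibitor of growth than chloro, even though the swap exchanges only a single heavy atom and adds a hydrogen-bond donor and a hydrogen-bond acceptor with no net charge. The other chloro group and the benzyl chain with its chloromethyl group are unchanged, so the step belongs to this one place, but nothing available explains why the number rises.

A single replacement cannot show whether the loss comes with amino alone or whether a methylamino, methoxy or methyl group at the same carbon would fare differently. As far as these compounds go, it also remains open whether the same amino swap would give a step of similar direction and size on compound 2, where the chain is joined through the other ring nitrogen.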